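Compound 4: pyridin-4-yl in place of 2-aminopyridin-3-yl

The source may report more compounds than this note shows. Statements on the series, on what has been measured and on what is new or still open speak of the compounds shown alone.

Compound 1 `COc1ccccc1Cn1c(-c2cccnc2N)nc2cccnc21` gives 58000 nM in an in vitro assay on Sf9 cells for inhibition of RAC-alpha serine/threonine-protein kinase (Homo sapiens), read by AlphaScreen, with a stated time of 20 min; a higher number here means a weaker inhibitor, a lower number a stronger inhibitor. Compound 2 `Nc1ncccc1-c1nc2cc(-c3cccnc3)cnc2n1-c1ccc(CNC(=O)c2ccccc2)cc1` gives 8 nM in this assay. Compound 3 `COc1ccccc1Cn1c(-c2cccnc2N)nc2cc(Br)cnc21` reaches only a limit of this assay, > 300000 nM, not a number.

Compound 3 therefore stands at the edge of what this assay reports (the limit of > 300000 nM in this assay, at which 1 of the 3 values shown sits). For the measured compounds named here, the one measured step that touches it, an at least 5.1-fold higher number from compound 1 to compound 3 (0.71 log units; beyond the scatter), concerns the bromo substitution and does not speak to the group that sits between the two ring nitrogen atoms of the shared core.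

Compound 4 `COc1ccccc1Cn1c(-c2ccncc2)nc2cc(Br)cnc21` differs from compound 3 by pyridin-4-yl in place of 2-aminopyridin-3-yl on an aromatic carbon. Going by the values given here, no measured step bears on this change. Compound 2 also carries a 2-aminopyridin-3-yl group and gives a far lower number than compound 3, but it differs from compound 3 in more than one place, so its value shows nothing about the present change alone. With compound 3 already at the limit, the step from compound 3 to compound 4 is expected to be a step that the limit leaves unreadable from compound 3 to compound 4, that is, no clear movement in either direction. Compound 4 is estimated to give about 400000 nM in this assay, in a range from 100000 nM to 1500000 nM, most probably again reported only as a limit.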

Compound 4, half-maximal inhibitory concentration: > 300000 nM
Compound 4 gave a limit, no number; the forecaster's own chance of this, stated with the estimate: 75%; the middle value is on the limit's open side.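

In this assay compound 4 gives > 300000 nM, which is a limit and not a number. Compound 3 also sits at a limit, so no step can be read between compound 3 and compound 4: the limit of > 300000 nM in this assay, at which 2 of the 4 values shown sit. The compounds shown leave open how pyridin-4-yl and 2-aminopyridin-3-yl compare on a compound that gives a readable number.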